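Five-membered heteroaryl swap at the distal biaryl position

This account rests on a few compounds, and the source may have more. Where it says the series, first, only, none or still open, it means among the compounds named here.

Measured so far, in an assay on isolated protein for inhibition of tyrosine-protein kinase receptor UFO (Homo sapiens), read by LC-MS; on this read-out higher numbers stand for weaker inhibition and lower numbers for stronger inhibition: compound 1 `CN(Cc1ccc2nccn2c1)c1nnc(-c2ccc(-c3ccccc3C#N)cc2)o1` gives 3980 nM; compound 2 `Cc1cc(-c2c(C)n[nH]c2C)ccc1-c1nnc(N(C)Cc2ccc3nccn3c2)o1` gives 5010 nM; compound 3 `Cc1cc(-c2c(C#N)nn(C)c2C)ccc1-c1nnc(N(C)Cc2ccc3nccn3c2)o1` gives 6310 nM.

Compound 3 holds the highest of the three numbers, but the step of a 1.3-fold higher number from compound 2 to compound 3 (0.10 log units; within the scatter) lies within the scatter, and the values of compound 1 and compound 3 also sit within the scatter of each other, so no order among the three is established.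

Compound 4 `Cc1cc(-c2c(C)nc(C)n2C)ccc1-c1nnc(N(C)Cc2ccc3nccn3c2)o1` is compound 3 with 1,2,4-trimethyl-1H-imidazol-5-yl in place of 3-cyano-1,5-dimethyl-1H-pyrazol-4-yl on an aromatic carbon. Going by the values given here, the only step at this position, a 1.3-fold higher number from compound 2 to compound 3 (0.10 log units; within the scatter), was within the scatter, so in this assay no step beyond the scatter is expected for the change to compound 4, an estimated 1.3-fold lower number from compound 3 to compound 4 (0.10 log units; within the scatter). Compound 4 is estimated at 5000 nM, range 2000 nM to 12500 nM.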

Compound 4, half-maximal inhibitory concentration: 3980 nM
The estimate for compound 4 lay 1.3-fold (0.10 log units) above the measured number; the measured number falls inside the stated range.
By their numbers in this assay, from the lowest: compounds 1, 4, 2 and 3 (each within the scatter of the next).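

Replacing the 3-cyano-1,5-dimethyl-1H-pyrazol-4-yl group with 1,2,4-trimethyl-1H-imidazol-5-yl gives a 1.6-fold lower number from compound 3 to compound 4 (0.20 log units; within the scatter); replacing the 3,5-dimethyl-1H-pyrazol-4-yl group with it gives a 1.3-fold lower number from compound 2 to compound 4 (0.10 log units; within the scatter). In this assay, a third five-membered ring with 2 hetero atoms and the removal of the nitrile therefore produce no step beyond the scatter at this position. No available evidence bears on this result.

Still open, as far as these compounds go, is whether any group here can move the number beyond the scatter. A carboxylic acid or an aminomethyl group in place of the five-membered ring would test this.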